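The source may hold more compounds than are shown below. What is called first, only, known or untested is meant among the compounds shown, and "the series" means these compounds.

Compound 1 `COc1ccc(-c2nc3cc(Cl)c(Cl)cc3[nH]2)cc1`, compound 2 `Nc1ccc(-c2nc3cc(Cl)c(Cl)cc3[nH]2)cc1` and compound 3 `Oc1ccc(-c2nc3cc(Cl)c(Cl)cc3[nH]2)cc1` share one core and differ in a single group. In an ADME assay on Vero cells (Chlorocebus sabaeus) for cytotoxicity (on this read-out lower numbers stand for higher toxicity in this test and higher numbers for lower toxicity in this test), compound 1 gives 30000 nM, the highest of the two numbers shown. Compound 3 gives 18000 nM, so that a 1.7-fold lower number from compound 1 to compound 3 (0.22 log units; within the scatter). For compound 2 the assay reports only a limit, >= 100000 nM. Compound 4 `COc1ccc(-c2nc3cc(Cl)c(Cl)cc3[nH]2)c([N+](=O)[O-])c1` differs from compound 1 by nitro in place of hydrogen on an aromatic carbon. Going by the values given here, no measured step adds a group of this kind; the steps seen, an at least 3.3-fold higher number from compound 1 to compound 2 (0.52 log units; beyond the scatter) and an at least 5.5-fold lower number from compound 2 to compound 3 (0.74 log units; beyond the scatter), exchange the methoxy group for another and give little guidance here. Among the compounds with values here, since compound 1 gives 30000 nM and no step bears on the change, compound 4 is expected to shift by no change at the digits printed from compound 1 to compound 4 (within the scatter), within the scatter. Compound 4 is estimated at 30000 nM, between 10000 nM and 90000 nM.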

Compound 4, half-maximal cytotoxic concentration: 80000 nM
The estimate for compound 4 lay 2.7-fold (0.43 log units) below the measured number; measured number inside the range.
By their numbers in this assay, from the lowest: compounds 3 and 1 (each within the scatter of the next); then compound 4. At a limit, above all of these: compound 2.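

Going by these compounds alone, this is the first step that keeps the methoxy group and changes another carbon of the same ring, and it shows that this carbon, ortho to a large group, also affects the read-out. In this assay, nitro in place of hydrogen gives a 2.7-fold higher number from compound 1 to compound 4 (0.43 log units; beyond the scatter), a modest move towards lower toxicity in this test. Nothing shown explains why the number rises.

As far as these compounds go, it remains open whether this rise is specific to nitro or would also appear with an amine or a methyl group on the same carbon. From the compounds shown here alone, whether nitro would have the same effect alongside the amino group of compound 2 or the hydroxy group of compound 3 is also open.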